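The source may report more compounds than this note shows. Statements on the series, on what has been measured and on what is new or still open speak of the compounds shown alone.

Cytotoxicity was followed in a functional assay on DU-145 cells (Homo sapiens) for cytotoxicity, read by trypan blue exclusion, with a stated time of 96 h; on this read-out higher numbers stand for weaker inhibition and lower numbers for stronger inhibition. Compound 1 `COc1ccc(CS(=O)(=O)/C=C/c2c(OC)cccc2OC)cc1[N+](=O)[O-]` gives 20000 nM in this assay. Compound 2 `COc1ccc(CS(=O)(=O)/C=C/c2c(OC)cccc2OC)cc1N` gives 50 nM in this assay. The two differ in one place, (amino in place of nitro on an aromatic carbon), and this change brought a 400-fold lower number from compound 1 to compound 2 (2.60 log units; beyond the scatter).

Compound 3 `COc1cc(OC)c(/C=C/[S+]([O-])Cc2ccc(OC)c([N+](=O)[O-])c2)c(OC)c1` gives 15000 nM in this assay. The difference between the core of compound 3 and the core of compound 1 is not broken down here; their two numbers lie within the usual scatter of each other, so nothing separates them.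

Compound 4 `COc1cc(OC)c(/C=C/[S+]([O-])Cc2ccc(OC)c(N)c2)c(OC)c1` has not yet been measured. It differs from compound 3 by amino in place of nitro on an aromatic carbon, the same change seen between compound 1 and compound 2, and the surroundings of the changed carbon are described in the same words in both pairs. Compound 4 is therefore expected to show a step of about a 300-fold lower number from compound 3 to compound 4 (2.48 log units; beyond the scatter), resting on the step from compound 1 to compound 2 of a 400-fold lower number from compound 1 to compound 2 (2.60 log units; beyond the scatter), with wider uncertainty because the two cores differ. Compound 4 is estimated at 50 nM, most likely between 10 nM and 300 nM.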

Compound 4, half-maximal inhibitory concentration: 40 nM
Compound 4: the middle estimate sits 1.3-fold (0.10 log units) above what was measured; measured number inside the range.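

In this assay, replacing nitro with amino on the core of compound 3 gave a 380-fold lower number from compound 3 to compound 4 (2.57 log units; beyond the scatter), and this step matches the one found on the core of compound 1: the same change on two cores in this assay, a 400-fold lower number (2.60 log units; beyond the scatter) from compound 1 to compound 2 and a 380-fold lower number (2.57 log units; beyond the scatter) from compound 3 to compound 4, 1.1-fold (0.03 log units) apart, within the scatter of two such steps For these two pairs, then, the change carries from one core to the other with its size intact, so the difference between the cores did not visibly alter its effect. This does not show that the step would hold on a third core or in another assay, and it does not explain why amino gives so much lower a number than nitro.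

The compounds shown leave open whether a group other than amino at this place, such as a hydroxyl group, a methylamino group or an acetamide, would also give a low number. For the compounds shown here, they also leave open which parts of the difference between the two cores matter on their own, since no pair here separates them.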